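This account rests on a few compounds, and the source may have more. Where it says the series, first, only, none or still open, it means among the compounds named here.

Compound 1 `O=C(Nc1cccc(-c2ccco2)c1)C1CCCN(C(=O)c2cc(C(F)(F)F)cc(C(F)(F)F)c2)C1` gives 0% in an ADME assay on PC-3 cells (Homo sapiens) for cytotoxicity, read by WST assay, tested at 100 uM; on this read-out higher numbers stand for more inhibition at the one concentration tested (going by the name of the read-out) and lower numbers for less inhibition. Compound 2 `O=C(Nc1cccc(CN2CCCC2)c1)C1CCCN(C(=O)c2cc(C(F)(F)F)cc(C(F)(F)F)c2)C1` gives 51% in this assay. Compound 3 `CCc1cccc(NC(=O)C2CCCN(C(=O)c3cc(C(F)(F)F)cc(C(F)(F)F)c3)C2)c1` gives 0% in this assay.

All three share one core and differ only in the group carried on the aromatic ring attached to the amide nitrogen. Compound 3 stands level with compound 1, the two together being the lowest of the three numbers; its nearest neighbour is compound 1, with no change at the digits printed from compound 1 to compound 3 (within the scatter), and its furthest is compound 2, with a number 51 percentage points lower from compound 2 to compound 3 (beyond the scatter). The only large movement seen is a number 51 percentage points higher from compound 1 to compound 2 (beyond the scatter).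

Compound 4 `O=C(Nc1ccc(Cl)cc1)C1CCCN(C(=O)c2cc(C(F)(F)F)cc(C(F)(F)F)c2)C1` is not yet measured. The change from compound 3 is 4-chlorophenyl in place of 3-ethylphenyl on an amide-type nitrogen. For the measured compounds named here, no measured step exchanges the whole aryl group on that amide nitrogen, so none bears on it directly. The steps that do touch that ring show that an ethyl and a furan-2-yl sit level, while only the (pyrrolidin-1-yl)methyl raises the number. Compound 4 carries neither, so compound 4 is expected to stay close to compound 3, with a step of a number 5 percentage points higher from compound 3 to compound 4 (within the scatter) expected to lie within the scatter. The estimate for compound 4 in this assay is 5%, with a range from 0% to 30%.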

Compound 4, a percentage reported as inhibition, at one concentration (the size of the read-out at that concentration, not a potency): 14%
Beside the measured number, compound 4's estimate is 9 percentage points below it; low and high end bracket the measured number.
By their numbers in this assay, from the lowest: compounds 1 and 3 (each within the scatter of the next); then compound 4; then compound 2.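

In this assay, the aryl group on the amide-type nitrogen can raise the number without carrying a (pyrrolidin-1-yl)methyl group: 4-chlorophenyl in place of 3-ethylphenyl gives a number 14 percentage points higher from compound 3 to compound 4 (beyond the scatter), and 4-chlorophenyl in place of 3-(furan-2-yl)phenyl gives a number 14 percentage points higher from compound 1 to compound 4 (beyond the scatter). The 3-((pyrrolidin-1-yl)methyl)phenyl group still stands apart, with a number 37 percentage points lower from compound 2 to compound 4 (beyond the scatter), so the two exchanges that lift the number off the lowest level differ in how far they lift it. Nothing at hand accounts for either step.

The 3-ethylphenyl to 4-chlorophenyl exchange alters both the group on the ring and the number it carries in the name, so the compounds shown cannot tell whether the chlorine itself or its place goes with the higher number, a question that 3-chlorophenyl or 4-ethylphenyl on the same nitrogen would address. They also leave open whether the high number of compound 2 needs the pyrrolidine ring in particular or would also appear with another amine, such as a dimethylaminomethyl or morpholinomethyl group, or with a carboxylic acid on that ring.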